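The source may hold more compounds than are shown below. What is called first, only, known or untested is meant among the compounds shown, and "the series" means these compounds.

Measured in an assay on CHO-K1 cells for displacement of a labelled ligand from melanin-concentrating hormone receptor 1 (Homo sapiens), read by scintillation proximity assay, with a stated time of 2 h; on this read-out higher numbers stand for weaker inhibition and lower numbers for stronger inhibition:

compound 1 `Cc1nc(N2CCC(N3CCOC3=O)CC2)nc2ccc(NC(=O)/C=C/c3ccc(OC(F)(F)F)cc3)cc12`, 41 nM
compound 2 `CCCC1(O)CCN(c2nc(C)c3cc(NC(=O)/C=C/c4ccc(Cl)cc4)ccc3n2)CC1`, 245 nM

Of these two numbers compound 1 has the lower one, which on this read-out means the stronger inhibition; compound 2 sits at a higher number, and the gap between the two lies beyond the usual scatter. The two compounds differ in more than one place, so no single change can be held responsible for that gap.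

Compound 3 `COCC(=O)NC1CCN(c2nc(C)c3cc(NC(=O)/C=C/c4ccc(OC(F)(F)F)cc4)ccc3n2)CC1` has not yet been measured in this assay. It differs from compound 1 in one place: ((methoxymethyl)carbonyl)amino in place of 2-oxo-1,3-oxazolidin-3-yl on a saturated ring carbon. The group that leaves and the group that enters are of the same size, both carry a carbonyl, and the main change is that the ring is opened into a chain that brings one hydrogen-bond donor with it.

Among the compounds with values here, no measured pair shows the effect of such a change here, so the expectation rests on the closeness of the two groups alone. The step from compound 1 to compound 3 is expected to be small, a 1.5-fold higher number from compound 1 to compound 3 (0.17 log units; within the scatter), and may not reach beyond the scatter. Compound 3 is therefore estimated at 60 nM, within a range from 20 nM to 200 nM.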

Compound 3, half-maximal inhibitory concentration: 32 nM
Estimate against measurement, compound 3: 1.9-fold (0.27 log units) above, within the range that was stated.
By their numbers in this assay, from the lowest: compounds 3 and 1 (each within the scatter of the next); then compound 2.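

Replacing the 2-oxo-1,3-oxazolidin-3-yl ring with the open ((methoxymethyl)carbonyl)amino chain on this saturated ring carbon gives a 1.3-fold lower number from compound 1 to compound 3 (0.11 log units; within the scatter) in this assay. In this one pair, then, the group on this carbon need not be closed into a ring to keep the reading of compound 1, and the hydrogen-bond donor that the chain brings leaves the number within the scatter. Nothing measured here explains why the ring and the chain read alike.

The compounds shown leave open whether the amide hydrogen of compound 3 plays any part, a question that a methyl group on the amide nitrogen could test. They also leave open how far this tolerance extends on the same carbon, for example to a free amine, a carboxylic acid or a longer chain, all of which would differ from both the ring and the chain compared here.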